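Amide series: expected value for the bromobenzyl analogue

The source may report more compounds than this note shows. Statements on the series, on what has been measured and on what is new or still open speak of the compounds shown alone.

In an assay on HEK293 cells for inhibition of Steryl-sulfatase (Homo sapiens), tested at 1 uM (on this read-out lower numbers stand for a weaker effect and higher numbers for a stronger effect at the one concentration tested), the measured compounds give:
compound 1 `CCN(Cc1ccc(F)cc1)c1cccc(C(=O)N2CCc3ccc(OS(N)(=O)=O)cc3C2)c1`: 66.5%
compound 2 `NS(=O)(=O)Oc1ccc2c(c1)CN(C(=O)c1cccc(N3CCCCC3)c1)CC2`: 11.9%
compound 3 `CN(C)CCN(CCN(C)C)c1cccc(C(=O)N2CCc3ccc(OS(N)(=O)=O)cc3C2)c1`: 17.1%

Compound 3 holds the second highest of the three numbers. Its nearest neighbour is compound 2, and that gap, a number 5.2 percentage points higher from compound 2 to compound 3 (within the scatter), lies within the scatter, so no order between the two is claimed. The furthest is compound 1, with the gap a number 49.4 percentage points lower from compound 1 to compound 3 (beyond the scatter), which is large and beyond the scatter.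

Compound 4 `CCN(Cc1cccc(Br)c1)c1cccc(C(=O)N2CCc3ccc(OS(N)(=O)=O)cc3C2)c1` is not yet measured. It differs from compound 3 in one place: (3-bromobenzyl)(ethyl)amino in place of bis(2-(dimethylamino)ethyl)amino on an aromatic carbon.

Within the data shown here, two measured steps bear on this change. The step of a number 49.4 percentage points lower from compound 1 to compound 3 (beyond the scatter) is the reverse of the present one in all but the halogen and its place on the benzyl ring, and the step of a number 54.6 percentage points lower from compound 1 to compound 2 (beyond the scatter) shows the same ethyl(4-fluorobenzyl)amino group standing far above a ring-only amine. Both point to a large rise in this assay when the benzyl-bearing amine returns, with some allowance for the bromine replacing fluorine.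

Compound 4 is therefore expected to give about 58% in this assay, within a range from 35% to 78%, an estimated step of a number 40.9 percentage points higher from compound 3 to compound 4 (beyond the scatter).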

Compound 4, a percentage reported as inhibition, at one concentration (the size of the read-out at that concentration, not a potency): 24.9%
The estimate for compound 4 lay 33.1 percentage points above the measured number; measured number below the stated range.
By their numbers in this assay, from the lowest: compounds 2, 3 and 4 (each within the scatter of the next, the first and the last beyond it); then compound 1.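

In this assay a benzyl ring on the ethyl-bearing amine does not by itself secure a high number at this position: the change of 4-fluorophenyl to 3-bromophenyl alone gives a number 41.6 percentage points lower from compound 1 to compound 4 (beyond the scatter) and takes most of the height of compound 1 away. The (3-bromobenzyl)(ethyl)amino group cannot be told apart from bis(2-(dimethylamino)ethyl)amino, with a number 7.8 percentage points higher from compound 3 to compound 4 (within the scatter) as the step, and it stands only modestly clear of piperidin-1-yl, with a number 13 percentage points higher from compound 2 to compound 4 (beyond the scatter) as the step, so among these compounds the high number belongs to the ethyl(4-fluorobenzyl)amino group alone. Nothing on hand accounts for the loss on changing the halogen and its place.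

As far as these compounds go, the halogen and its place on the benzyl ring change together here, so it stays open which of the two carries the step; a benzyl group with bromine where compound 1 has fluorine, or with fluorine where compound 4 has bromine, would separate them. Also open, from the compounds shown here alone, is how much the ethyl on that nitrogen contributes, which a methyl or a propyl group there would show.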